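From Phenoxy to Cyano: What to Expect for Compound 4

The compounds below may be only part of what the source reports. "The series", "measured", "known", "first", "only" and "open" are said of these compounds alone.

Compound 1 `O[C@H](COCCOC[C@@H](O)Cc1cn(Cc2ccc(Oc3ccccc3)cc2)nn1)Cc1ccc(-c2ccccc2)cc1` gives 4500 nM in a functional assay on SGC-7901 cells (Homo sapiens) for inhibition, read by MTT assay, with a stated time of 72 h; on this read-out lower numbers stand for stronger inhibition of growth and higher numbers for weaker inhibition of growth.
Compound 2 `O[C@H](COCCOC[C@@H](O)Cc1cn(-c2cccnc2)nn1)Cc1ccc(-c2ccccc2)cc1` gives 29800 nM in this assay.
Compound 3 `O[C@H](COCCOC[C@@H](O)Cc1c[nH]nn1)Cc1ccc(-c2ccccc2)cc1` gives > 100000 nM in this assay, which is a limit of the assay rather than a number.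

Among the numbers in hand, compound 1 stands lowest, and its nearest neighbour, compound 2, sits well beyond the scatter above it. Going by the values given here, the one step between single-point neighbours is an at least 3.3-fold higher number from compound 2 to compound 3 (0.52 log units; beyond the scatter); that step ends at the limit of > 100000 nM in this assay, at which 1 of the 3 values shown sits, so only its lower bound is known. It concerns the group on the aromatic nitrogen, not the benzyl ring, and so bears only loosely on the change now at hand.

Compound 4 `N#Cc1ccc(Cn2cc(C[C@H](O)COCCOC[C@@H](O)Cc3ccc(-c4ccccc4)cc3)nn2)cc1` differs from compound 1 in one place: cyano in place of phenoxy on an aromatic carbon. The large, ring-bearing phenoxy gives way to the small cyano, para to a large group. Among the compounds with values here, no measured pair tests a change of this kind, so the expectation rests on the general sensitivity the series shows to changes at the periphery. A modest weakening is expected, not a collapse. For compound 4 the estimated value in this assay is 12000 nM, within 4000 nM to 40000 nM, which is expected to amount to a 2.7-fold higher number from compound 1 to compound 4 (0.43 log units; beyond the scatter).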

Compound 4, concentration for 50% growth inhibition: 7700 nM
For compound 4 the middle estimate is 1.6-fold (0.19 log units) above the measured one, within the range that was stated.
By their numbers in this assay, from the lowest: compounds 1 and 4 (each within the scatter of the next); then compound 2. At a limit, above all of these: compound 3.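

In this assay, going by these compounds alone, exchanging phenoxy for cyano gives a 1.7-fold higher number from compound 1 to compound 4 (0.23 log units; within the scatter), so at this place, para to a large group, the 7 heavy atoms and ring of phenoxy can give way to the 2 heavy atoms of cyano without a change beyond the scatter; no earlier pair tested this place at all. Within the data shown here, the group on the aromatic nitrogen, the only place the earlier compounds had probed, now gains a second reading, since 4-cyanobenzyl in place of pyridin-3-yl gives a 3.9-fold lower number from compound 2 to compound 4 (0.59 log units; beyond the scatter). Against hydrogen on that nitrogen the step is larger, an at least 12-fold lower number from compound 3 to compound 4 (1.11 log units; beyond the scatter), though only its lower bound is known, compound 3 being a limit and not a number: the limit of > 100000 nM in this assay, at which 1 of the 4 values shown sits.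

From the compounds shown here alone, whether this place tolerates any group is still open, as a carboxylic acid or an amine para to the large group could behave quite differently from phenoxy and cyano, and a plain benzyl group would show what either one adds. Going by these compounds, the length of the link also stays untested, and a phenethyl group on the aromatic nitrogen would speak to it.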